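Shared-core anilides: phenoxymethyl to 3,4-dimethoxyphenyl

The compounds below may be only part of what the source reports. "The series", "measured", "known", "first", "only" and "open" are said of these compounds alone.

Measured so far:
compound 1 `O=C(CSc1nnc(NC(=O)COc2ccccc2)s1)Nc1ccc(Br)cc1`: > 100000 nM
compound 2 `CCn1c(CNc2ccc(OC)cc2)nnc1SCC(=O)Nc1ccc(Cl)cc1`: 39500 nM

In a functional assay on HCT-116 cells (Homo sapiens) for antiproliferative activity, read by MTT assay, with a stated time of 72 h (on this read-out lower numbers stand for stronger inhibition and higher numbers for weaker inhibition), compound 1 is reported only as a limit of the assay, > 100000 nM, so no number is known for it. Among the compounds with values here, compound 2, built on a different core, gives 39500 nM in this assay; no step between the two is computed, and the two values show only that compound 2 returns a number where compound 1 does not. Compound 3 `COc1ccc(C(=O)Nc2nnc(SCC(=O)Nc3ccc(Br)cc3)s2)cc1OC` differs from compound 1 by 3,4-dimethoxyphenyl in place of phenoxymethyl on a carbonyl carbon. Within the data shown here, because compound 1 stands at the limit of > 100000 nM in this assay, at which 1 of the 2 values shown sits, no measured step from it is available to scale this change. The step of an at least 1.2-fold lower number from compound 1 to compound 3 (0.09 log units; that floor lies within the scatter) is therefore expected to be small, at most a modest shift toward stronger inhibition and possibly none beyond the scatter. Compound 3 is estimated at 80000 nM, between 20000 nM and 300000 nM, with a real chance that only a limit is reported again.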

Compound 3, half-maximal inhibitory concentration: 66600 nM
The estimate for compound 3 lay 1.2-fold (0.08 log units) above the measured number, and the stated range covers the measured number.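

In this assay, the position on a carbonyl carbon of the shared core now returns a number: with 3,4-dimethoxyphenyl in place of phenoxymethyl, compound 3 reads 66600 nM. The change amounts to an at least 1.5-fold lower number from compound 1 to compound 3 (0.17 log units; that floor lies within the scatter), so a real shift toward stronger inhibition is not established by the floor alone. The true size of the step cannot be read, because compound 1 is reported only as a limit: the limit of > 100000 nM in this assay, at which 1 of the 3 values shown sits.

Still open, from the compounds shown here alone, is whether a plain phenyl without the methoxy groups would read like compound 3, and whether a longer chain or a terminal amine on the same carbonyl carbon would lower the number further. Within the data shown here, compound 2 differs from both in more than one place and gives no step on this question.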